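The source may report more compounds than this note shows. Statements on the series, on what has been measured and on what is new or still open speak of the compounds shown alone.

In a functional assay on cells (Platelet, Homo sapiens) for inhibition (on this read-out lower numbers stand for stronger inhibition and higher numbers for weaker inhibition), compound 1 `CCOC(=O)c1ccc(-c2nn(Cc3cccc(OC)c3)c3ccccc23)cc1` gives 260 nM, a measured number that marks what a compound with this kind of core can do. Compound 2 `CCCOC(=O)c1ccc(-c2nn(Cc3ccccc3)c3ccccc23)cc1` gives only a limit of the assay, > 10000 nM, so it has no measured number and sits at the weak end of what has been seen so far.

The next compound, compound 3 `OCc1ccc(-c2nn(Cc3ccccc3)c3ccccc23)cc1`, keeps the core of compound 2 and changes one place: hydroxymethyl in place of propoxycarbonyl on an aromatic carbon, para to a large group (hydroxymethyl in place of propoxycarbonyl on an aromatic carbon). Among the measured compounds shown here, no tested pair isolates a single change, so any expectation rests on thin ground. For the measured compounds named here, the only support is compound 1 at 260 nM, which shows that a measurable inhibition is within reach for this kind of core. A moderate move towards stronger inhibition in this assay is therefore expected, though the assay could again report only a limit. The expected step is an at least 3.3-fold lower number from compound 2 to compound 3 (0.52 log units; beyond the scatter). For compound 3 the estimated value is 3000 nM, with an expected range from 500 nM to 10000 nM.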

Compound 3, half-maximal inhibitory concentration: > 10000 nM
Compound 3: no number, only a limit; the forecaster's own chance of this, stated with the estimate: 35%; middle value at least 3.3-fold (0.52 log units) away from the limit.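

Among the compounds shown here, compound 2 and compound 3 both give only a limit and no measured number in this assay, so no step between them can be read, because both stop at the same boundary: the limit of > 10000 nM in this assay, at which 2 of the 3 values shown sit.

The compounds shown leave open whether hydroxymethyl in place of propoxycarbonyl changes inhibition at all, and by how much.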